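A Bromine Step Repeated on a Second Core

A few compounds are considered here, and "the series" means these few. Any claim that something is new, unique, unknown or untested is made for them only; others in the source may bear on it.

The study measures cytotoxicity in an ADME assay on XF498 cells (Homo sapiens) for cytotoxicity; a higher number here means that more compound is needed for the effect, a lower number that less compound is needed. Compound 2, `O=C1NC[C@@H](c2c[nH]c3ccccc23)N=C1c1c[nH]c2ccccc12`, gives 24.1 ug/mL in this assay. Compound 1, `O=C1NC[C@@H](c2c[nH]c3cc(Br)ccc23)N=C1c1c[nH]c2ccccc12`, gives 8.3 ug/mL. Between them lies one change, (bromo in place of hydrogen on an aromatic carbon), and it made a 2.9-fold lower number from compound 2 to compound 1 (0.46 log units; beyond the scatter).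

Compound 3, `O=C(C1=NC(c2c[nH]c3ccccc23)CN1)c1c[nH]c2cc(Br)ccc12`, shares much with compound 2 but is built on a different core; how the two cores differ is not broken down here. In this assay compound 3 reaches only > 30 ug/mL, which is a limit of the assay and not a number. The limit is worth noting: the limit of > 30 ug/mL in this assay, at which 1 of the 3 values shown sits.

Compound 4, `O=C(C1=NC(c2c[nH]c3cc(Br)ccc23)CN1)c1c[nH]c2cc(Br)ccc12`, has not yet been measured in this assay. It differs from compound 3 by bromo in place of hydrogen on an aromatic carbon, the same change that separates compound 1 from compound 2, and it is the second time this change occurs among these four compounds.

The expected step is an at least 1.5-fold lower number from compound 3 to compound 4 (0.17 log units; that floor lies within the scatter), and that expectation rests on compound 1, whose step a 2.9-fold lower number from compound 2 to compound 1 (0.46 log units; beyond the scatter) shows what the same change did on the other core. Because compound 3 sits at the limit (the limit of > 30 ug/mL in this assay, at which 1 of the 3 values shown sits), the starting point is uncertain, so the range is kept wide. Compound 4 is estimated at 20 ug/mL, between 9 ug/mL and 45 ug/mL.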

Compound 4, concentration for half-maximal effect: 5.16 ug/mL
Estimate against measurement, compound 4: 3.9-fold (0.59 log units) above; measured number outside the range, below it.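

In this assay, bromo in place of hydrogen on an aromatic carbon gives an at least 5.8-fold lower number from compound 3 to compound 4 (0.76 log units; beyond the scatter), so the number fell with this change on the second core as it did on the first, and both steps lie beyond the scatter: the same change on two cores in this assay, a 2.9-fold lower number (0.46 log units; beyond the scatter) from compound 2 to compound 1 and an at least 5.8-fold lower number (0.76 log units; beyond the scatter) from compound 3 to compound 4; the limit leaves it open whether they differ Compound 3 stands at > 30 ug/mL, which is a limit of the assay and not a number, so the new step gives only a floor and not a size: the limit of > 30 ug/mL in this assay, at which 1 of the 4 values shown sits. The two pairs therefore show that the direction of the change carried over from one core to the other, but they do not show that its size carried over, whether equal, larger or smaller, and two pairs establish no rule for any further core in this series.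

The compounds shown leave open whether another group at the same place, such as chloro, methoxy or an amine, would lower the number on either core as bromo does. They also leave open how large the step on the second core really is, and whether either step would hold in cells other than those of this assay.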